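Swapping Isopropyl for an Oxygen-Containing Ring: Stability Outlook

The source may report more compounds than this note shows. Statements on the series, on what has been measured and on what is new or still open speak of the compounds shown alone.

Compound 1 `COc1cc(-c2cnn3cc(OC)c(C(C)C)nc23)ccn1` is the starting point. Among the measured compounds shown here, in an ADME assay on microsomes from liver (Rattus norvegicus) for metabolic stability, with a stated time of 60 min, tested at 1 uM (a higher number here means that more of the compound is left, a lower number that less of the compound is left), compound 1 gives 14%, the highest of the three numbers so far. Compound 2 `COc1cc(-c2cnn3cc(OC)c(N(C)C)nc23)ccn1` gives 3% in this assay, and compound 3 `COc1cc(-c2cnn3cc(OC)c(C4CCCC4)nc23)ccn1` gives 7%. The step of a number 7 percentage points lower from compound 1 to compound 3 (within the scatter) lies within the scatter, whereas the step of a number 11 percentage points lower from compound 1 to compound 2 (beyond the scatter) goes beyond it.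

Compound 4 `COc1cc(-c2cnn3cc(OC)c([C@H]4COC(C)(C)C4)nc23)ccn1` has not yet been measured. It differs from compound 1 in one place: a group of 7 heavy atoms (6 carbon, 1 oxygen; one five-membered non-aromatic ring with 1 hetero atom) in place of a group of 3 heavy atoms (3 carbon; no ring), on an aromatic carbon. For the measured compounds named here, the step that bears most on this is the one from compound 1 to compound 3, which also put a ring in place of the isopropyl and stayed within the scatter. The step to compound 2, which put in the dimethylamino group, was larger, but no dimethylamino group enters here. So a small drop, or no change beyond the scatter, is expected. For compound 4 a value of 11% is expected, with a range from 4% to 24%. This estimate would mean a step of a number 3 percentage points lower from compound 1 to compound 4 (within the scatter).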

Compound 4, percent of the compound remaining: 30%
Compound 4: middle estimate off by 19 percentage points, on the low side; the measured number lies above the stated range.
By their numbers in this assay, from the lowest: compounds 2, 3 and 1 (each within the scatter of the next, the first and the last beyond it); then compound 4.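

In this assay this carbon proves able to carry a larger group with a higher number as the result, since the ring with one oxygen gives a number 16 percentage points higher from compound 1 to compound 4 (beyond the scatter) and neither earlier replacement of isopropyl did so. A ring alone does not explain this, as the change from the all-carbon ring gives a number 23 percentage points higher from compound 3 to compound 4 (beyond the scatter) and the change from dimethylamino gives a number 27 percentage points higher from compound 2 to compound 4 (beyond the scatter) on the same core. No measurement here explains why the number rises.

The compounds shown leave open whether the ring oxygen or the additional carbon atoms account for the rise, and how the opposite form of the defined stereocentre would behave. Also open, going by these compounds, is how a smaller oxygen ring such as oxetane or a six-membered one such as tetrahydropyran would fare at this carbon.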